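A few compounds are considered here, and "the series" means these few. Any claim that something is new, unique, unknown or untested is made for them only; others in the source may bear on it.

Working notes on the series. Compound 2 `COc1cc(C(=O)/C=C\Nc2ccc(-c3nc4cc(OC)c(OC)c(OC)c4s3)cc2C)cc(OC)c1OC` gives 12900 nM in a functional assay on MDA-MB-231 cells (Homo sapiens) for antiproliferative activity, read by sulforhodamine B assay, with a stated time of 48 h; a higher number here means a weaker inhibitor, a lower number a stronger inhibitor. Among the three numbers in hand it stands second highest: compound 3 `COc1ccc(C(=O)/C=C\Nc2ccc(-c3nc4cc(OC)c(OC)c(OC)c4s3)cc2C)cc1O` gives 12400 nM and compound 1 `COc1cc(C(=O)/C=C\Nc2ccc(-c3nc4cc(OC)c(OC)c(OC)c4s3)cc2)c(Br)c(OC)c1OC` gives 15600 nM, and both sit within the scatter of compound 2, so no order among the three can be read. Among the compounds with values here, the one single-site step, a 1.0-fold lower number from compound 2 to compound 3 (0.02 log units; within the scatter), shows that swapping the aryl group on the carbonyl carbon leaves the number essentially where it was.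

Compound 4 `COc1cc(C(=O)/C=C\Nc2ccc(-c3nc4cc(OC)c(OC)c(OC)c4s3)cc2C)c(Br)c(OC)c1OC` is compound 2 with one change: bromo in place of hydrogen on an aromatic carbon. Within the data shown here, no measured step isolates a bromo on this ring. Compound 1 carries the bromo but lacks the methyl of compound 2, and its value and that of compound 2 are within the scatter of each other, so the bromo is the only hint available and it points to no shift. A step beyond the scatter is therefore not expected in this assay; the expected step is a 1.2-fold higher number from compound 2 to compound 4 (0.07 log units; within the scatter). Compound 4 is estimated at 15000 nM, within 7000 nM to 32000 nM.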

Compound 4, half-maximal inhibitory concentration: 7300 nM
Compound 4: middle estimate off by 2.1-fold (0.31 log units), on the high side; the measured number falls inside the stated range.
By their numbers in this assay, from the lowest: compounds 4, 3, 2 and 1 (each within the scatter of the next, the first and the last beyond it).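

In this assay, the bromo in place of hydrogen on the aromatic carbon ortho to a large group gives a 1.8-fold lower number from compound 2 to compound 4 (0.25 log units; within the scatter), so even with the methyl present, no effect of the bromo can be claimed at this position. Within the data shown here, with the bromo held constant, adding the methyl gives a 2.1-fold lower number from compound 1 to compound 4 (0.33 log units; beyond the scatter), the first single-site step to pass the scatter, though only modestly. Nothing measured is at hand to account for either step.

The compounds shown leave open whether a chloro or an amine on the same aromatic carbon would read like the bromo, and whether the methyl step holds on a core without the bromo. On these data alone, an ethyl group or a longer chain in place of the methyl also remains open.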